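A few compounds are considered here, and "the series" means these few. Any claim that something is new, unique, unknown or untested is made for them only; others in the source may bear on it.

Measured compounds:
- compound 1 `N#Cc1ccccc1C1OCC(C/C=C\CCC(=O)O)C(c2cccnc2)O1`; in an assay for inhibition of prostacyclin synthase (Homo sapiens), using microsomes (a lower number here means a stronger inhibitor, a higher number a weaker inhibitor), compound 1 gives > 100000 nM, a limit of the assay.
- compound 2 `O=C(O)CC/C=C\CC1COC(c2ccc(Cl)cc2Cl)OC1c1cccnc1`; in this assay compound 2 gives 2500 nM.
- compound 3 `CC(C)(Oc1ccccc1F)C1OCC(C/C=C\CCC(=O)O)C(c2cccnc2)O1`; in this assay compound 3 gives < 1000 nM, a limit of the assay.

Compound 2 holds the only number shown. Compound 3 sits at the limit of < 1000 nM in this assay, at which 1 of the 3 values shown sits. Compound 1 sits at the limit of > 100000 nM in this assay, at which 1 of the 3 values shown sits.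

Compound 4 `CC(C)(Cc1ccccc1)C1OCC(C/C=C\CCC(=O)O)C(c2cccnc2)O1` is not yet measured; it differs from compound 2 by 1-benzyl-1-methylethyl in place of 2,4-dichlorophenyl on a saturated ring carbon. Among the measured compounds shown here, the one measured step at this saturated ring carbon, an at least 40-fold lower number from compound 1 to compound 2 (1.60 log units; beyond the scatter), swaps a different pair of groups and so bears only loosely on the change. Compound 3, with its own branched group there, reaches a limit rather than a number; the two values show no more than that. The step of a 2.8-fold lower number from compound 2 to compound 4 (0.44 log units; beyond the scatter) is therefore expected to be small, toward a lower number, possibly within the scatter. Compound 4 is estimated at 900 nM, within 150 nM to 5000 nM.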

Compound 4, half-maximal inhibitory concentration: 13000 nM
Compound 4: middle estimate off by 14-fold (1.16 log units), on the low side, outside the stated range (above it).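

In this assay, 1-benzyl-1-methylethyl at this saturated ring carbon gives a 5.2-fold higher number from compound 2 to compound 4 (0.72 log units; beyond the scatter), so this branched group ranks behind 2,4-dichlorophenyl. The end of the branched group matters: benzyl in place of 2-fluorophenoxy gives an at least 13-fold higher number from compound 3 to compound 4 (1.11 log units; beyond the scatter), a step read against the limit held by compound 3. The same group still ranks ahead of 2-cyanophenyl, with an at least 7.6-fold lower number from compound 1 to compound 4 (0.88 log units; beyond the scatter), a step read against the limit held by compound 1.

Open, on these data alone, is whether the ether oxygen or the fluorine of compound 3 carries its advantage over compound 4. Also open, as far as these compounds go, is how an amine or a longer chain would read in place of the benzyl.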